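Swapping Hydroxy for Bromo on the Benzyl Arm

The source may hold more compounds than are shown below. What is called first, only, known or untested is meant among the compounds shown, and "the series" means these compounds.

Three measured compounds share one core and differ only in the group on the amine nitrogen. Compound 1 `COc1cc(Oc2cccc(Nc3ccccc3)c2)cc(OC)c1CNCc1ccc(Cl)cc1` carries a 4-chlorobenzyl group, and in a functional assay on DLD-1 cells (Homo sapiens) for inhibition, read by MTT assay, with a stated time of 72 h (a lower number here means a stronger inhibitor, a higher number a weaker inhibitor), compound 1 gives 3740 nM. Compound 2 `COc1cc(Oc2cccc(Nc3ccccc3)c2)cc(OC)c1CNC1CC1` carries a cyclopropyl group instead. In this assay compound 2 reaches only a limit of the assay, > 20000 nM. Compound 3 `COc1cc(Oc2cccc(Nc3ccccc3)c2)cc(OC)c1CNCc1ccc(O)cc1` carries a 4-hydroxybenzyl group, and in this assay compound 3 gives 2690 nM, the lowest of the two numbers, though the gap to its nearest neighbour lies within the scatter: a 1.4-fold lower number from compound 1 to compound 3 (0.14 log units; within the scatter). Moving from either benzyl group to cyclopropyl gave a large step, an at least 5.3-fold higher number from compound 1 to compound 2 (0.72 log units; beyond the scatter) and an at least 7.4-fold lower number from compound 2 to compound 3 (0.87 log units; beyond the scatter).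

Compound 4 `COc1cc(Oc2cccc(Nc3ccccc3)c2)cc(OC)c1CNCc1ccc(Br)cc1` has not yet been measured. It differs from compound 3 by bromo in place of hydroxy on an aromatic carbon. Going by the values given here, the one measured step that bears on this is the exchange of chloro for hydroxy, a 1.4-fold lower number from compound 1 to compound 3 (0.14 log units; within the scatter), which stayed within the scatter. Bromo, like chloro, brings no hydrogen-bond donor or acceptor, so no step beyond the scatter is expected. Compound 4 is therefore estimated at about 3200 nM, within a range of 1500 nM to 7000 nM. This estimate means an expected step of a 1.2-fold higher number from compound 3 to compound 4 (0.08 log units; within the scatter).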

Compound 4, half-maximal inhibitory concentration: 3520 nM
Estimate against measurement, compound 4: 1.1-fold (0.04 log units) below; measured number inside the range.
By their numbers in this assay, from the lowest: compounds 3, 4 and 1 (each within the scatter of the next). At a limit, above all of these: compound 2.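

In this assay, the position on the benzyl ring tolerates all three groups tested so far: bromo in place of hydroxy gives a 1.3-fold higher number from compound 3 to compound 4 (0.12 log units; within the scatter), and bromo in place of chloro gives a 1.1-fold lower number from compound 1 to compound 4 (0.03 log units; within the scatter), so a group with a hydrogen-bond donor and acceptor and two groups with neither all stay within the scatter of one another. The 4-bromobenzyl group in place of cyclopropyl gives an at least 5.6-fold lower number from compound 2 to compound 4 (0.75 log units; beyond the scatter), so the third benzyl compound also stands clearly apart from compound 2. For compound 2, the number is a limit and not a measured value: the limit of > 20000 nM in this assay, at which 1 of the 4 values shown sits.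

From the compounds shown here alone, whether any group at this ring position can move the number beyond the scatter remains open, for example an amine or a carboxylic acid. Also open, going by these compounds, is how a longer chain between the ring and the amine nitrogen would read.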